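The source may report more compounds than this note shows. Statements on the series, on what has been measured and on what is new or still open speak of the compounds shown alone.

Working notes on the series. Compound 1 `CCOC(=O)c1ccc(-c2nn(Cc3ccccc3OC)c3ccccc23)cc1`, compound 2 `CCOC(=O)c1ccc(-c2nn(Cc3ccc(OC)cc3)c3ccccc23)cc1` and compound 3 `CCOC(=O)c1ccc(-c2nn(Cc3cccnc3)c3ccccc23)cc1` share one core and differ only in the group carried on the aromatic nitrogen. In a functional assay on cells (Platelet, Homo sapiens) for inhibition (a lower number here means a stronger inhibitor, a higher number a weaker inhibitor), compound 1 gives > 10000 nM, which is a limit of the assay and not a number. Compound 2 gives > 10000 nM in this assay, again a limit. Compound 3 gives > 10000 nM in this assay, also a limit. Compound 3 thus stands at the limit of > 10000 nM in this assay, at which 3 of the 3 values shown sit, with nothing in the numbers to set it apart from the other two. The steps a step that the two limits leave unreadable from compound 1 to compound 2, a step that the two limits leave unreadable from compound 1 to compound 3 and a step that the two limits leave unreadable from compound 2 to compound 3 have no readable size, so no direction can be drawn from them. Compound 4 `CCOC(=O)c1ccc(-c2nn(-c3ccccc3)c3ccccc23)cc1` has not been measured; the change from compound 3 is phenyl in place of (pyridin-3-yl)methyl on an aromatic nitrogen. Among the compounds with values here, the three limits show only that the core has stayed weak in this assay with each group tried on that nitrogen. For compound 4 the step that the limit leaves unreadable from compound 3 to compound 4 is expected to stay inside that picture. Compound 4 is estimated at 15000 nM, within 3000 nM to 60000 nM, and most likely reported as a limit once more.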

Compound 4, half-maximal inhibitory concentration: > 10000 nM
Compound 4 ended at the assay's limit; the forecaster's own chance of this, stated with the estimate: 75%; the middle value lies beyond the limit too.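

No step among compound 1, compound 2, compound 3 and compound 4 can be read, since each value is a limit of the assay and not a number: the limit of > 10000 nM in this assay, at which 4 of the 4 values shown sit.

The compounds shown leave open whether any group on that aromatic nitrogen of the shared core gives a readable value in this assay.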